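Cyclopropyl in place of hydrogen on the shared core

The source may report more compounds than this note shows. Statements on the series, on what has been measured and on what is new or still open speak of the compounds shown alone.

Compound 1 `NS(=O)(=O)c1ccc(CNc2nc(Nc3cccc(NC(=O)N4CCCC4)c3)ncc2Br)cc1`: > 10000 nM in an assay on HEK293 cells for displacement of a labelled ligand from serine/threonine-protein kinase 17A (Homo sapiens), read by NanoBRET (on this read-out higher numbers stand for weaker inhibition and lower numbers for stronger inhibition), a limit of the assay.
Compound 2 `NS(=O)(=O)c1ccc(CNc2ccnc(Nc3cccc(NC(=O)N4CCCC4)c3)n2)cc1`: > 10000 nM in this assay, a limit of the assay.

Compound 2 therefore stands at the limit of > 10000 nM in this assay, at which 2 of the 2 values shown sit. Within the data shown here, the only measured step, a step that the two limits leave unreadable from compound 1 to compound 2, cannot be read between two limits. Compound 3 `NS(=O)(=O)c1ccc(CNc2nc(Nc3cccc(NC(=O)N4CCCC4)c3)ncc2C2CC2)cc1` differs from compound 2 by cyclopropyl in place of hydrogen on an aromatic carbon. Among the measured compounds shown here, no measured step bears on this change, so neither size nor direction can be drawn from the data. Compound 3 is accordingly expected to remain near the limit, estimated at 8000 nM with a range from 2000 nM to 30000 nM. The expected step of an at least 1.2-fold lower number from compound 2 to compound 3 (0.09 log units; that floor lies within the scatter) is thus small.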

Compound 3, half-maximal inhibitory concentration in the serine/threonine-protein kinase 17A assay: > 10000 nM
Compound 3 was reported as a limit (the forecaster's own chance of this, stated with the estimate: 60%); at least 1.2-fold (0.09 log units) between middle value and limit.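

In the serine/threonine-protein kinase 17A assay compound 3 gives > 10000 nM, a limit of the assay.

No step among compound 1, compound 2 and compound 3 can be read in the serine/threonine-protein kinase 17A assay, as all three values are limits of the assay: the limit of > 10000 nM in the serine/threonine-protein kinase 17A assay, at which 3 of the 3 values shown sit.

The compounds shown leave open how hydrogen, bromo and cyclopropyl on this aromatic carbon rank in the serine/threonine-protein kinase 17A assay.

In a physicochemical assay for solubility, in phosphate buffer, measured as kinetic solubility, with a stated time of 24 h, at pH 7.4 (a lower number here means a less soluble compound, a higher number a more soluble compound), compound 2 gives 169000 nM and compound 3 gives 164000 nM. The step in the physicochemical assay is a 1.0-fold lower number from compound 2 to compound 3 (0.01 log units; within the scatter), so these two values lie within the scatter of each other.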